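The source may report more compounds than this note shows. Statements on the series, on what has been measured and on what is new or still open speak of the compounds shown alone.

Measured so far in a functional assay on BT-549 cells (Homo sapiens) for antiproliferative activity, with a stated time of 48 h; on this read-out lower numbers stand for stronger inhibition of growth and higher numbers for weaker inhibition of growth:
compound 1 `Cc1cc(O)c(C2=NN(c3ccc(S(N)(=O)=O)cc3)C(c3ccccc3Cl)C2)cc1Cl`, 2160 nM
compound 2 `Cc1cc(O)c(C2=NN(c3ccc(S(N)(=O)=O)cc3)C(/C=C/c3ccccc3)C2)cc1Cl`, 6120 nM

Going by the values given here, compound 2 stands highest of these two numbers; the only step seen is a 2.8-fold higher number from compound 1 to compound 2 (0.45 log units; beyond the scatter). Compound 3 `COc1ccc(C2CC(c3cc(Cl)c(C)cc3O)=NN2c2ccc(S(N)(=O)=O)cc2)cc1OC` differs from compound 2 in one place: 3,4-dimethoxyphenyl in place of 2-phenylethenyl on a saturated ring carbon. From the compounds shown here alone, compound 3 is expected to give a somewhat lower number, a 2.2-fold lower number from compound 2 to compound 3 (0.34 log units; beyond the scatter), because a 2.8-fold higher number from compound 1 to compound 2 (0.45 log units; beyond the scatter) was observed when a group bearing a six-membered aromatic ring directly on that saturated ring carbon was exchanged for 2-phenylethenyl, and compound 3 brings such a ring back, although the 3,4-dimethoxyphenyl group itself is untested. Compound 3 is therefore estimated at about 2800 nM, within 1100 nM to 7000 nM.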

Compound 3, concentration for 50% growth inhibition: 3030 nM
For compound 3 the middle estimate is 1.1-fold (0.03 log units) below the measured one; the measured number falls inside the stated range.
By their numbers in this assay, from the lowest: compounds 1 and 3 (each within the scatter of the next); then compound 2.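

In this assay, 3,4-dimethoxyphenyl on the saturated ring carbon gives a 2.0-fold lower number from compound 2 to compound 3 (0.31 log units; beyond the scatter), so a second group with its six-membered aromatic ring attached directly there also gives a lower number than 2-phenylethenyl. Against 2-chlorophenyl, the change gives a 1.4-fold higher number from compound 1 to compound 3 (0.15 log units; within the scatter), so these two ring-bearing groups cannot be told apart, although only 3,4-dimethoxyphenyl has oxygen atoms. No measurement shown explains these results. Still open, from the compounds shown here alone, is how an unsubstituted phenyl compares at this position. Going by these compounds, a saturated cyclohexyl ring or a carboxylic acid on the ring also remains unexplored.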